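The compounds below may be only part of what the source reports. "The series", "measured", "known", "first", "only" and "open" are said of these compounds alone.

Measured in a functional assay on HGC-27 cells (Homo sapiens) for cytotoxicity, read by MTT assay, with a stated time of 48 h; a higher number here means a weaker inhibitor, a lower number a stronger inhibitor:
- Compound 1 `COc1ccc(/C=C/C(=O)/C=C/c2cc3ccccc3nc2Oc2ccc(Br)cc2)cc1OC`: > 10000 nM, a limit
- Compound 2 `COc1cc(OC)c(/C=C/C(=O)/C=C/c2cc3ccccc3nc2Oc2ccc(Br)cc2)c(OC)c1`: > 10000 nM, a limit

Compound 2 gives no number, only the limit > 10000 nM. The two measured compounds share one standing: the limit of > 10000 nM in this assay, at which 2 of the 2 values shown sit.

Compound 3 `COc1cc(OC)c(/C=C/C(=O)/C=C/c2cc3ccccc3nc2Oc2cccc(Cl)c2)c(OC)c1` has 3-chlorophenyl in place of 4-bromophenyl on an oxygen on an aromatic ring.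

For the measured compounds named here, the only measured step is a step that the two limits leave unreadable from compound 1 to compound 2. It concerns a different place, and it has no readable size, so it offers no measure for this change. No direction can be drawn from it. No step beyond the scatter is therefore expected in this assay, and another limit is a likely outcome.

The expected change is a step that the limit leaves unreadable from compound 2 to compound 3. For compound 3 the estimated value is 15000 nM, with an expected range from 6000 nM to 40000 nM.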

Compound 3, half-maximal inhibitory concentration: > 10000 nM
Compound 3 was reported as a limit (the forecaster's own chance of this, stated with the estimate: 70%); the middle value lies beyond the limit too.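

Compound 2 and compound 3 are both reported only as limits in this assay, so the step between them, 3-chlorophenyl in place of 4-bromophenyl, cannot be read: the limit of > 10000 nM in this assay, at which 3 of the 3 values shown sit.

The compounds shown leave open whether either change alters cytotoxicity at all, and what would give a measurable value.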